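The source may report more compounds than this note shows. Statements on the series, on what has been measured and on what is new or still open speak of the compounds shown alone.

Working notes on the series. The shared core is seen in compound 1 `O=C(Nc1ccc(I)cc1)Nc1nc(-c2cc3ccccc3o2)cs1`, compound 2 `O=C(Nc1ccc(F)cc1)Nc1nc(-c2cc3ccccc3o2)cs1` and compound 3 `O=C(Nc1nc(-c2cc3ccccc3o2)cs1)Nc1ccccc1F`. In a physicochemical assay, with a stated time of 6 min (on this read-out lower numbers stand for stronger inhibition and higher numbers for weaker inhibition), compound 1 gives 62000 nM, compound 2 gives 1130 nM and compound 3 gives 2630 nM. Compound 2 thus stands lowest of the three numbers, with a 2.3-fold higher number from compound 2 to compound 3 (0.37 log units; beyond the scatter) as the nearest neighbour and a 55-fold lower number from compound 1 to compound 2 (1.74 log units; beyond the scatter) as the furthest.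

Compound 4 `O=C(Nc1ccc(F)cc1)Nc1nc(-c2cc3cc([N+](=O)[O-])ccc3o2)cs1` is not yet measured. It differs from compound 2 by nitro in place of hydrogen on an aromatic carbon. Among the measured compounds shown here, none of the measured steps touches this part of the core: a 55-fold lower number from compound 1 to compound 2 (1.74 log units; beyond the scatter), a 24-fold lower number from compound 1 to compound 3 (1.37 log units; beyond the scatter) and a 2.3-fold higher number from compound 2 to compound 3 (0.37 log units; beyond the scatter) all change the group on the amide-type nitrogen. No step beyond the scatter is therefore expected in this assay, in either direction. Compound 4 is expected to give about 1200 nM, within 350 nM to 4500 nM. The expected step is a 1.1-fold higher number from compound 2 to compound 4 (0.03 log units; within the scatter).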

Compound 4, half-maximal inhibitory concentration: 123000 nM
The estimate for compound 4 lay 100-fold (2.01 log units) below the measured number; the measured number lies above the stated range.
By their numbers in this assay, from the lowest: compound 2; then compound 3; then compounds 1 and 4 (each within the scatter of the next).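

On the six-membered aromatic ring of carbon only, part of the fused system, nitro in place of hydrogen gives a 110-fold higher number from compound 2 to compound 4 (2.04 log units; beyond the scatter) in this assay, towards weaker inhibition. The read-out therefore responds to this part of the core, and not only to the group on the amide-type nitrogen. No measurement shown explains the size of this step. The compounds shown leave open whether this step belongs to nitro itself or to any group on this carbon. An amine or a methoxy group here would separate the two.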